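Changing the sulfur substituent toward a 4-methylbenzyl group

The compounds below may be only part of what the source reports. "The series", "measured", "known", "first", "only" and "open" are said of these compounds alone.

Of the compounds shown here, three sharing one core have been measured in a functional assay on HGC-27 cells (Homo sapiens) for inhibition, read by MTT assay, with a stated time of 72 h; a higher number here means a weaker inhibitor, a lower number a stronger inhibitor. Compound 1 `Cc1cc(N2CC[C@@H](C)[C@@H](N(C)c3ncnc4[nH]ccc34)C2)n2nc(SCC3CC3)nc2n1` gives 21400 nM. Compound 2 `C=CCSc1nc2nc(C)cc(N3CC[C@@H](C)[C@@H](N(C)c4ncnc5[nH]ccc45)C3)n2n1` gives 35200 nM, and compound 3 `C#CSc1nc2nc(C)cc(N3CC[C@@H](C)[C@@H](N(C)c4ncnc5[nH]ccc45)C3)n2n1` gives 35100 nM. Compound 2 sits at the top of the three numbers, but its step of a 1.6-fold higher number from compound 1 to compound 2 (0.22 log units; within the scatter) and its step of a 1.0-fold lower number from compound 2 to compound 3 (0.00 log units; within the scatter) are both within the scatter, so the three compounds cannot be told apart on these data. The unmeasured compound 4 `Cc1ccc(CSc2nc3nc(C)cc(N4CC[C@@H](C)[C@@H](N(C)c5ncnc6[nH]ccc56)C4)n3n2)cc1` differs from compound 2 in one place: 4-methylphenyl in place of vinyl on a saturated chain carbon bound to a sulfur. The measured steps that bear on this change are those altering the group on the sulfur, namely a 1.6-fold higher number from compound 1 to compound 2 (0.22 log units; within the scatter), a 1.6-fold higher number from compound 1 to compound 3 (0.21 log units; within the scatter) and a 1.0-fold lower number from compound 2 to compound 3 (0.00 log units; within the scatter), and none of them moved beyond the scatter. The step from compound 2 to compound 4 is therefore expected to be small, a 1.2-fold lower number from compound 2 to compound 4 (0.07 log units; within the scatter), with no clear direction. Compound 4 is expected to give about 30000 nM in this assay, within a range from 10000 nM to 90000 nM.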

Compound 4, half-maximal inhibitory concentration: 15200 nM
The estimate for compound 4 lay 2.0-fold (0.30 log units) above the measured number; the measured number falls inside the stated range.
By their numbers in this assay, from the lowest: compounds 4, 1, 3 and 2 (each within the scatter of the next, the first and the last beyond it).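

In this assay, the sulfur substituent now produces steps beyond the scatter, both modest (a 2.3-fold lower number from compound 2 to compound 4 (0.36 log units; beyond the scatter); a 2.3-fold lower number from compound 3 to compound 4 (0.36 log units; beyond the scatter)), whereas every earlier change of this group stayed within it. The 4-methylbenzyl group therefore separates compound 4 from the allyl and ethynyl compounds, but not from the cyclopropylmethyl compound (a 1.4-fold lower number from compound 1 to compound 4 (0.15 log units; within the scatter)), which is within the scatter, so the larger group gives no measurable advantage over every smaller one. No available evidence accounts for this difference among the sulfur substituents. The compounds shown leave open whether the aromatic ring alone is enough or its methyl group also contributes, which a plain benzyl group on the sulfur would test. They also leave open how a phenethyl group or a longer alkyl chain would compare.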